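Pyrrolyl in place of fluorophenyl on a thiosemicarbazone

The source may report more compounds than this note shows. Statements on the series, on what has been measured and on what is new or still open speak of the compounds shown alone.

Values in a functional assay on U-251 cells (Homo sapiens) for inhibition, read by sulforhodamine B assay, with a stated time of 48 h; on this read-out higher numbers stand for weaker inhibition of growth and lower numbers for stronger inhibition of growth:
Compound 1, `CC1=CC[C@H](C(C)(C)N=C=S)CC1`: 29100 nM
Compound 2, `CC1=CC[C@H](C(C)(C)NC(=S)N/N=C/c2ccc(N(C)C)cc2)CC1`: 57700 nM
Compound 3, `CC1=CC[C@H](C(C)(C)NC(=S)N/N=C/c2ccc(F)cc2)CC1`: > 100000 nM

Compound 3 stands at the edge of what this assay can report: its value is a limit and not a number, and it sits at the limit of > 100000 nM in this assay, at which 1 of the 3 values shown sits. Compound 2 gives 57700 nM. Within the data shown here, the one measured step that touches compound 3 is an at least 1.7-fold higher number from compound 2 to compound 3 (0.23 log units; that floor lies within the scatter), and because of the limit of > 100000 nM in this assay, at which 1 of the 3 values shown sits, its true size is open upward.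

Compound 4, `CC1=CC[C@H](C(C)(C)NC(=S)N/N=C/c2ccc[nH]2)CC1`, differs from compound 3 in one place: 1H-pyrrol-2-yl in place of 4-fluorophenyl on a carbon with a double bond to nitrogen. Among the measured compounds shown here, no measured pair shows this change on the shared core, so the only guide is that compound 2 and compound 3 both lie far out in this assay, the latter as a limit. The expected step is therefore small or none beyond the scatter, with the direction uncertain; the account expects an at least 1.1-fold lower number from compound 3 to compound 4 (0.04 log units; that floor lies within the scatter), but notes that the starting point is a limit. Compound 4 is accordingly estimated at 90000 nM, within a range from 30000 nM to 250000 nM, and a fair chance remains that this assay again reports only a limit.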

Compound 4, concentration for 50% growth inhibition: 80 nM
Compound 4: middle estimate off by 1100-fold (3.05 log units), on the high side; measured number outside the range, below it.
By their numbers in this assay, from the lowest: compound 4; then compounds 1 and 2 (each within the scatter of the next). At a limit, above all of these: compound 3.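

In this assay, the group on the carbon with a double bond to nitrogen proves decisive on this shared core: placing 1H-pyrrol-2-yl there in place of 4-fluorophenyl gives an at least 1200-fold lower number from compound 3 to compound 4 (3.09 log units; beyond the scatter), whereas the earlier change at this place, an at least 1.7-fold higher number from compound 2 to compound 3 (0.23 log units; that floor lies within the scatter), did not show a step beyond the scatter. Compound 2, which also has a six-membered aromatic ring of carbon only at this place, gives 57700 nM, while compound 4 gives 80 nM, so the low number goes with the 1H-pyrrol-2-yl and with neither of the two carbon rings shown. The size of the new step is only a floor and remains open upward, since compound 3 carries a limit and not a number: the limit of > 100000 nM in this assay, at which 1 of the 4 values shown sits.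

The compounds shown leave open whether the step belongs to the hydrogen on the pyrrole nitrogen or to the five-membered ring as such, a question that a methyl on that nitrogen, or a furyl or thienyl ring at the same place, would address. They also leave open whether the attachment point matters, as a comparison with 1H-pyrrol-3-yl would show.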